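Anilide substituent series: the nitro to chloro step

The source may hold more compounds than are shown below. What is called first, only, known or untested is meant among the compounds shown, and "the series" means these compounds.

Measured compounds in a functional assay on Molt4/C8 cells (Homo sapiens) for cytotoxicity; on this read-out higher numbers stand for weaker inhibition and lower numbers for stronger inhibition:
compound 1, `COc1ccc(NC(=O)/C=C/C(=O)N2C/C(=C\c3ccc([N+](=O)[O-])cc3)C(=O)/C(=C/c3ccc([N+](=O)[O-])cc3)C2)cc1` — 940 nM
compound 2, `O=C(/C=C/C(=O)N1C/C(=C\c2ccc([N+](=O)[O-])cc2)C(=O)/C(=C/c2ccc([N+](=O)[O-])cc2)C1)Nc1ccc([N+](=O)[O-])cc1` — 430 nM

Among the compounds with values here, compound 2 holds the lower of the two numbers on record in this assay; its only neighbour is compound 1, and the two are separated by a 2.2-fold lower number from compound 1 to compound 2 (0.34 log units; beyond the scatter).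

Compound 3, `O=C(/C=C/C(=O)N1C/C(=C\c2ccc([N+](=O)[O-])cc2)C(=O)/C(=C/c2ccc([N+](=O)[O-])cc2)C1)Nc1ccc(Cl)cc1`, is not yet measured. It differs from compound 2 by chloro in place of nitro on an aromatic carbon. Within the data shown here, the only measured step at this site is a 2.2-fold lower number from compound 1 to compound 2 (0.34 log units; beyond the scatter), which set nitro against methoxy. Chloro is neither of those groups, and no other compound in the series carries chloro at this site, so that step bears on the new one only loosely: it shows that the group at this site moves the number by a modest amount, and that nitro gave the lower value. Since compound 2 with nitro gives 430 nM, removing nitro is expected to shift the number upward, though by less than the whole methoxy-to-nitro step.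

For compound 3 the expected value in this assay is 650 nM, with a range from 300 nM to 1400 nM. The expected step is a 1.5-fold higher number from compound 2 to compound 3 (0.18 log units; within the scatter), close to the edge of the scatter.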

Compound 3, half-maximal inhibitory concentration: 1200 nM
The estimate for compound 3 lay 1.8-fold (0.27 log units) below the measured number; the measured number falls inside the stated range.
By their numbers in this assay, from the lowest: compound 2; then compounds 1 and 3 (each within the scatter of the next).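

In this assay, replacing nitro with chloro on the anilide ring gives a 2.8-fold higher number from compound 2 to compound 3 (0.45 log units; beyond the scatter), a step larger than the one measured for nitro in place of methoxy, so chloro does not retain the value seen with nitro. Chloro and methoxy cannot be separated at this site, with a 1.3-fold higher number from compound 1 to compound 3 (0.11 log units; within the scatter), which leaves compound 2 as the only one of the three whose steps to both others lie beyond the scatter, and the series now reads as nitro against the other two groups rather than as a graded run of three. Nothing on record explains why nitro stands apart from chloro and methoxy here.

Within the data shown here, with only three groups at this site, it remains open whether the lower number is particular to nitro or would also appear with a nitrile, a trifluoromethyl, or a carboxylic acid in the same place. An amine or a bare hydrogen at this site would show whether chloro and methoxy sit at a baseline for the anilide ring or are themselves shifted from it.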